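A few compounds are considered here, and "the series" means these few. Any claim that something is new, unique, unknown or untested is made for them only; others in the source may bear on it.

Measured compounds:
- compound 1 `O=C(O)c1cc(-c2cnc(C(=O)CCc3ccc(-c4ccccc4)cc3)o2)ccn1`: 50 nM
- compound 2 `CN(C)C(=O)c1cnc(C(=O)CCc2ccc(COc3ccccc3)cc2)o1`: 6.7 nM

Both compounds were tested in an assay for inhibition of Fatty-acid amide hydrolase 1 (Rattus norvegicus); on this read-out lower numbers stand for stronger inhibition and higher numbers for weaker inhibition. Compound 1 gives 50 nM, the higher of the two numbers. Compound 2 gives 6.7 nM, a lower number, and the gap between them lies beyond the usual scatter of this assay. The two compounds differ in more than one place, so their values can only be compared as a pair, not taken apart into single changes.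

Compound 3 `NC(=O)c1cccc(-c2cnc(C(=O)CCc3ccc(-c4ccccc4)cc3)o2)n1` has not yet been measured. It keeps the core of compound 1 and its whole tail and changes one group on an aromatic carbon of the core: 6-carbamoylpyridin-2-yl in place of 2-carboxypyridin-4-yl on an aromatic carbon

Among the compounds with values here, no measured pair shows this exact change, so the expectation rests on compound 1 alone. The group that enters carries a primary amide rather than a carboxylic acid and is attached at a different ring position. The estimate for compound 3 in this assay is 8 nM, within a range from 1.5 nM to 40 nM. This corresponds to an expected step of a 6.3-fold lower number from compound 1 to compound 3 (0.80 log units; beyond the scatter), a decrease beyond the scatter, though an outcome close to compound 1 cannot be ruled out.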

Compound 3, inhibition constant: 1.2 nM
Beside the measured number, compound 3's estimate is 6.7-fold (0.82 log units) above it; measured number below the stated range.
By their numbers in this assay, from the lowest: compound 3; then compound 2; then compound 1.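

Replacing 2-carboxypyridin-4-yl with 6-carbamoylpyridin-2-yl on the aromatic carbon next to the ring oxygen gives a 42-fold lower number from compound 1 to compound 3 (1.62 log units; beyond the scatter) in this assay, which shows that the group at this position can change the read-out by a large amount. Within the data shown here, the earlier comparison could not show this, as its two compounds differ in more than one place and gave no single step. The two groups have the same counts of heavy atoms, hydrogen-bond donors and hydrogen-bond acceptors, so these counts do not separate them, and no measurement shown here accounts for the size of the step.

On these data alone, this single step changes both the carboxylic acid to a primary amide and the way the pyridine ring is attached, so the share of each change stays open; a 6-carboxypyridin-2-yl or a 2-carbamoylpyridin-4-yl group at this position would be needed to pull them apart. As far as these compounds go, it also remains unknown whether the primary amide itself matters, or whether a nitrile, a methyl ester or an amine on the same pyridine ring would give a similar number.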